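The source may hold more compounds than are shown below. What is called first, only, known or untested is meant among the compounds shown, and "the series" means these compounds.

Three compounds of one series carry a shared core with an aryl group on the five-membered ring. Compound 1, `O=C1COc2ccc(-c3[nH]c(-c4ccc(C(F)(F)F)cc4)nc3-c3ccccc3)cc2N1`, gives 0.6% in a functional assay on MV4-11 cells (Homo sapiens) for cytotoxicity, read by colorimetric assay and MTT assay, with a stated time of 3 days, tested at 20 uM; a higher number here means a weaker effect of the compound at the concentration tested, a lower number a stronger effect. Compound 2, `O=C1COc2ccc(-c3nn(-c4ccc(Br)cc4)cc3-c3ccccc3)cc2N1`, gives 91.5% in this assay, and compound 3, `O=C1COc2ccc(-c3nn(-c4ccc(F)cc4)cc3-c3ccccc3)cc2N1`, gives 92.6% in this assay. Compound 3 thus holds the highest of the three numbers; compound 2 lies within the scatter of it, while compound 1 lies far below, beyond the scatter.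

The step from compound 3 to compound 4, `O=C1COc2ccc(-c3nn(-c4ccc(Cl)cc4)cc3-c3ccccc3)cc2N1`, is this: chloro in place of fluoro on an aromatic carbon. Among the measured compounds shown here, the one measured step of the same kind is a number 1.1 percentage points higher from compound 2 to compound 3 (within the scatter), a swap of one halogen for another on the same aromatic carbon that left the number within the scatter. On that basis no step beyond the scatter is expected from compound 3 to compound 4 in this assay, and the expected step is a number 1.6 percentage points lower from compound 3 to compound 4 (within the scatter). Compound 4 is therefore estimated at 91% in this assay, with a range from 78% to 100%.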

Compound 4, a percentage reported as activity, at one concentration (the size of the read-out at that concentration, not a potency): 91.9%
Compound 4: the middle estimate sits 0.9 percentage points below what was measured; the range from low to high includes it.
By their numbers in this assay, from the lowest: compound 1; then compounds 2, 4 and 3 (each within the scatter of the next).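

In this assay, the chloro compound adds a third halogen at this aromatic carbon, para to a large group, and gives two further steps: a number 0.7 percentage points lower from compound 3 to compound 4 (within the scatter) and a number 0.4 percentage points higher from compound 2 to compound 4 (within the scatter). Together with the earlier bromo-to-fluoro step, every pair among compound 2, compound 3 and compound 4 now lies within the scatter, so the choice among these three halogens does not separate the compounds at this position in this assay. No measured information on the cause of this flat result is available here.

Going by these compounds, whether a non-halogen group at this carbon, such as an amine, a carboxylic acid or a longer alkyl chain, would give a step beyond the scatter remains open. Also open is which feature accounts for the distance of compound 1 from this halogen set, as compound 1 differs from them in more than one place.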